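Nitrophenyl swap from compound 2 to compound 3

This account rests on a few compounds, and the source may have more. Where it says the series, first, only, none or still open, it means among the compounds named here.

In an ADME assay on L02 cells (Homo sapiens) for cytotoxicity, read by MTT assay, with a stated time of 24 h (a lower number here means a stronger inhibitor, a higher number a weaker inhibitor), compound 1 `COc1cc(/C=C2\CN(C)C/C(=C\c3ccc(C#N)cc3)C2=O)cc(OC)c1` gives 14000 nM and compound 2 `COc1cc(/C=C2\CN(C)C/C(=C\c3cc(OC)c(OC)c(OC)c3)C2=O)cc(OC)c1` gives 14600 nM. These two values lie within the scatter of each other, so compound 2 stands level with compound 1 on the numbers available.

Compound 3 `COc1cc(/C=C2\CN(C)C/C(=C\c3cccc([N+](=O)[O-])c3)C2=O)cc(OC)c1OC` has not yet been measured in this assay. Relative to compound 2, it carries 3-nitrophenyl in place of 3,5-dimethoxyphenyl on a double-bonded chain carbon bound to a double-bonded ring carbon. For the measured compounds named here, no pair of measured compounds differs in one place only, so the series offers no direct precedent for this change.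

Going by the values given here, the sole guide is that compound 1 and compound 2 carry different substituted phenyl groups yet remain within the scatter of each other. On that thin basis, the expected step of a 1.1-fold lower number from compound 2 to compound 3 (0.05 log units; within the scatter) in this assay is none beyond the scatter, with no direction favoured. For compound 3 the estimated value is 13000 nM, with an expected range of 6500 nM to 26000 nM.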

Compound 3, half-maximal inhibitory concentration: 13600 nM
Compound 3: the middle estimate sits 1.0-fold (0.02 log units) below what was measured; the range from low to high includes it.
By their numbers in this assay, from the lowest: compounds 3, 1 and 2 (each within the scatter of the next).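

For the compounds shown here, the step of a 1.1-fold lower number from compound 2 to compound 3 (0.03 log units; within the scatter) in this assay is the first comparison that differs in one place only, so the earlier level reading between compounds now has a direct single-change counterpart. On a double-bonded chain carbon bound to a double-bonded ring carbon, 3-nitrophenyl can stand in place of 3,5-dimethoxyphenyl with no change beyond the scatter, even though the two groups differ in their substituents and their atoms. This single exchange gives no reason for that outcome, and no supporting measurement bears on it.

The compounds shown include no step at this position that goes beyond the scatter, so how far the number can move here remains open, and one exchange between two substituted phenyl groups cannot define a trend. A carboxylic acid or an amine on the phenyl ring, or a longer chain in place of that ring, would test this position with a different kind of group, and whether either would shift the number in this assay remains unanswered.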